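This account rests on a few compounds, and the source may have more. Where it says the series, first, only, none or still open, it means among the compounds named here.

Measured in an ADME assay on HepG2 cells (Homo sapiens) for cytotoxicity, with a stated time of 72 h; on this read-out higher numbers stand for an effect only at larger amounts of compound and lower numbers for an effect already at smaller amounts:
- Compound 1 `Cc1cc(NC(=O)Nc2ccc(C)c(Cl)c2)c2ccccc2n1`: > 25000 nM
- Compound 2 `CCc1ccc(NC(=O)Nc2cc(C)nc3ccccc23)cc1`: 17000 nM

The result for compound 1, > 25000 nM, is a limit of the assay and not a number. Going by the values given here, compound 2, at 17000 nM, therefore holds the only true number so far. Compound 3 `COC(=O)c1ccc(NC(=O)Nc2cc(C)nc3ccccc23)cc1` departs from compound 2 in one place: methoxycarbonyl in place of ethyl on an aromatic carbon, para to a large group (methoxycarbonyl in place of ethyl on an aromatic carbon).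

Among the compounds with values here, no measured pair differs in just one place, so the data give no size of step to borrow for this assay. The expectation is therefore anchored on compound 2 at 17000 nM, with no shift beyond the scatter in either direction. The expected change is small: a 1.2-fold higher number from compound 2 to compound 3 (0.07 log units; within the scatter). For compound 3 the estimated value is 20000 nM, with an expected range of 9000 nM to 35000 nM.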

Compound 3, half-maximal effective concentration: 20000 nM
Compound 3: middle estimate and measured number agree at the digits printed, and the stated range covers the measured number.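

In this assay, going by these compounds alone, methoxycarbonyl in place of ethyl on an aromatic carbon, para to a large group, gives a 1.2-fold higher number from compound 2 to compound 3 (0.07 log units; within the scatter), the first step between compounds that differ in one place. This position therefore takes a group with hydrogen-bond acceptors and a double bond outside aromatic rings, neither of which ethyl has, without a change beyond the scatter. The series also has an upper end that limits how far any weaker effect could be read: the limit of > 25000 nM in this assay, at which 1 of the 3 values shown sits.

On these data alone, whether an amine, a carboxylic acid or a longer chain at this position would also stay within the scatter remains open. So does whether a group here could bring the number down to clearly smaller amounts of compound, since this single step shows no such movement.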